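This account rests on a few compounds, and the source may have more. Where it says the series, first, only, none or still open, it means among the compounds named here.

In a functional assay on HT-29 cells (Homo sapiens) for cytotoxicity, read by sulforhodamine B assay, with a stated time of 48 h (a lower number here means a stronger inhibitor of growth, a higher number a weaker inhibitor of growth), the two measured compounds sit at the weak end. Compound 1, `COc1cc(Cc2c[nH]c3ccccc23)c(N)c(OC)c1OC`, gives only the limit > 100000 nM, which is a limit of the assay and not a number, as noted in the limit of > 100000 nM in this assay, at which 1 of the 2 values shown sits. For the measured compounds named here, compound 2, `COc1ccc2c(Cc3cc(OC)c(OC)c(OC)c3N)c[nH]c2c1`, is the one compound with an actual number: in this assay compound 2 gives 74800 nM. Going by the values given here, the single measured step runs an at least 1.3-fold lower number from compound 1 to compound 2 (0.12 log units; that floor lies within the scatter), so the effect of the added methoxy cannot be called real. Compound 3, `COc1cc(Cc2c[nH]c3cc(F)ccc23)c(N)c(OC)c1OC`, differs from compound 2 by fluoro in place of methoxy on an aromatic carbon. Among the compounds with values here, no measured step has this exchange, and the only step lies within the scatter, so the step to compound 3 is expected to be small, with a slightly higher number more likely than a lower one. Compound 3 is therefore estimated at 100000 nM, between 40000 nM and 250000 nM, a step of a 1.3-fold higher number from compound 2 to compound 3 (0.13 log units; within the scatter) expected from compound 2.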

Compound 3, concentration for 50% growth inhibition: "not active" (no number reported)
No number was reported for compound 3, and the estimate cannot be compared.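

For the compounds shown here, compound 3 is reported as "not active" in this assay with no number, so no new step from compound 2 to compound 3 can be read. Compound 1 stays at a limit of the assay: the limit of > 100000 nM in this assay, at which 1 of the 3 values shown sits. The compounds shown leave open how far fluoro in place of methoxy changes growth inhibition.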